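Undecyl ester against 4-bromophenyl ester at the assay limit

The source may hold more compounds than are shown below. What is called first, only, known or untested is meant among the compounds shown, and "the series" means these compounds.

In a functional assay on RAW264.7 cells (Mus musculus) for inhibition, read by Griess assay, with stated times of 30 min and 24 h (a higher number here means a weaker inhibitor, a lower number a stronger inhibitor), compound 1 (`C[C@@H](CC[C@@H]1[C@@]2(C)CCCC(C)(C)[C@@H]2CC[C@@]1(C)O)CC(=O)O`) reads > 50000 nM as a limit of the assay and not a number. Compound 2 (`C[C@H](CCOC(=O)c1ccc(Br)cc1)CC[C@@H]1[C@@]2(C)CCCC(C)(C)[C@@H]2CC[C@@]1(C)O`) reads > 50000 nM in this assay as a limit as well. For the measured compounds named here, no measured step exists to scale from, and no number is available for either compound.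

Going by the values given here, compound 3 (`CCCCCCCCCCCC(=O)OCC[C@@H](C)CC[C@@H]1[C@@]2(C)CCCC(C)(C)[C@@H]2CC[C@@]1(C)O`) keeps the shared core and has undecyl in place of 4-bromophenyl on a carbonyl carbon as its one change from compound 2.

Compound 2 sits at the limit of > 50000 nM in this assay, at which 2 of the 2 values shown sit, and this is the sole basis for expecting no step beyond the scatter in this assay for the change. Any move that does appear is expected to be toward stronger inhibition, since a weaker reading would simply stay at the limit. The estimated change is a number no higher from compound 2 to compound 3 (the limit leaves the size open) and remains an expectation. For compound 3 the expected half-maximal inhibitory concentration is 50000 nM with an estimated range of 15000 nM to 100000 nM and a fair chance that the reading is again only a limit.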

Compound 3, half-maximal inhibitory concentration: > 50000 nM
Compound 3 was reported as a limit; the forecaster's own chance of this, stated with the estimate: 65%; the middle value sits exactly at the limit.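

In this assay compound 3 gives > 50000 nM, a limit of the assay and not a number. For the compounds shown here, compound 2 also reads as a limit, so no step from compound 2 to compound 3 can be read. Still open is whether undecyl and 4-bromophenyl differ at all, and how strong an inhibitor any of the three compounds is: the limit of > 50000 nM in this assay, at which 3 of the 3 values shown sit.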